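A Fluorine Added to the Phenyl Arm of Compound 1

The source may report more compounds than this note shows. Statements on the series, on what has been measured and on what is new or still open speak of the compounds shown alone.

Of the compounds shown here, three sharing one core have been measured in a functional assay on A549 cells (Homo sapiens) for antiproliferative activity, read by MTT assay, with a stated time of 48 h; on this read-out lower numbers stand for stronger inhibition and higher numbers for weaker inhibition. Compound 1 `O=C(/C=C\Nc1ccc(F)cc1)c1cn(-c2ccccc2)nc1-c1ccccc1` gives 4670 nM. Compound 2 `O=C(/C=C\Nc1ccc(O)cc1)c1cn(-c2ccccc2)nc1-c1ccccc1` gives 3210 nM, and compound 3 `COc1ccc(N/C=C\C(=O)c2cn(-c3ccccc3)nc2-c2ccccc2)cc1` gives 3250 nM. The steps among them, a 1.5-fold lower number from compound 1 to compound 2 (0.16 log units; within the scatter) and a 1.4-fold lower number from compound 1 to compound 3 (0.16 log units; within the scatter) as well as a 1.0-fold higher number from compound 2 to compound 3 (0.01 log units; within the scatter), all lie within the scatter, so the three numbers cannot be told apart with confidence.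

Compound 4 `O=C(/C=C\Nc1ccc(F)cc1)c1cn(-c2ccccc2)nc1-c1ccc(F)cc1` differs from compound 1 by fluoro in place of hydrogen on an aromatic carbon; seen one bond further out, a phenyl becomes a 4-fluorophenyl. Among the measured compounds shown here, none of the measured steps touches this phenyl: each of them changes the group on the other aromatic ring, the one attached to the nitrogen, and each stayed within the scatter. For the measured compounds named here, there is therefore no measured step that bears directly on the change from compound 1 to compound 4, and no ground to expect a step beyond the scatter in either direction. Compound 4 is estimated to give 4200 nM, with a range from 1500 nM to 12000 nM, meaning an expected step of a 1.1-fold lower number from compound 1 to compound 4 (0.05 log units; within the scatter).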

Compound 4, half-maximal inhibitory concentration: 5780 nM
Compound 4: middle estimate off by 1.4-fold (0.14 log units), on the low side, and the stated range covers the measured number.
By their numbers in this assay, from the lowest: compounds 2, 3, 1 and 4 (each within the scatter of the next).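

Among the compounds shown here, until now every measured step changed the group on the ring attached to the nitrogen, and compound 4 gives the first reading on the phenyl itself. In this assay the change from phenyl to 4-fluorophenyl gives a 1.2-fold higher number from compound 1 to compound 4 (0.09 log units; within the scatter) and so the two compounds cannot be told apart, which means this position, para to a large group, accepts a fluoro in place of hydrogen without a step beyond the scatter. No measurement at hand offers an explanation for this result.

The compounds shown hold only hydrogen or fluoro at this position, so a single small swap is all that can be read there. From the compounds shown here alone, whether a larger or different group in the same place, such as an amine, a carboxylic acid or a longer chain, would give a step beyond the scatter remains open.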